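The compounds below may be only part of what the source reports. "The series", "measured", "known", "first", "only" and "open" are said of these compounds alone.

Measured in a functional assay on U-87MG ATCC cells (Homo sapiens) for antiproliferative activity, with a stated time of 3 days; a lower number here means that less compound is needed, a higher number that more compound is needed for the effect:
- compound 1 `Oc1ccc(CN(Cc2ccccc2C(F)(F)F)Cc2ccc(O)c3ncccc23)c2cccnc12`: < 0.2 uM
- compound 2 `Oc1ccc(CN(Cc2ccc(OC(F)(F)F)cc2)Cc2ccc(O)c3ncccc23)c2cccnc12`: "not determined" (no result reported)
- compound 3 `Oc1ccc(CN(Cc2ccc(O)c3ncccc23)CC2CCCO2)c2cccnc12`: 5 uM

Going by the values given here, compound 3, at 5 uM, holds the only actual number. Compound 1 gives < 0.2 uM, which is a limit and not a number. Compound 2 has no result to compare, its entry reading "not determined" (no result reported).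

Compound 4 `Cn1cccc1CN(Cc1ccc(O)c2ncccc12)Cc1ccc(O)c2ncccc12` keeps the shared core of compound 3 and carries 1-methyl-1H-pyrrol-2-yl in place of oxolan-2-yl on a saturated chain carbon bound to an amine nitrogen.

Among the compounds with values here, only one measured step bears on this change: an at least 25-fold higher number from compound 1 to compound 3 (1.39 log units; beyond the scatter). There, oxolan-2-yl replaced 2-(trifluoromethyl)phenyl at that same place, and the number in this assay rose by a large margin. Compound 4 again has an aromatic ring there, though a five-membered one, and it lacks the trifluoromethyl group. A single step from compound 1 is thin support, so only part of that large step is expected to return, in the direction of a lower number. The step expected is a 3.3-fold lower number from compound 3 to compound 4 (0.52 log units; beyond the scatter). For compound 4 the estimated value is 1.5 uM, with an expected range from 0.3 uM to 6 uM.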

Compound 4, concentration for half-maximal effect: 2 uM
For compound 4 the middle estimate is 1.3-fold (0.12 log units) below the measured one, and the stated range covers the measured number.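

Replacing the non-aromatic oxolan-2-yl with the aromatic 1-methyl-1H-pyrrol-2-yl on a saturated chain carbon bound to an amine nitrogen gives a 2.5-fold lower number from compound 3 to compound 4 (0.40 log units; beyond the scatter), so in this assay this position responds to a change between two five-membered rings and not only to the removal of 2-(trifluoromethyl)phenyl. An aromatic five-membered ring at this place does not, however, bring the number back to that of the 2-(trifluoromethyl)phenyl compound, as the other new step shows: an at least 10-fold higher number from compound 1 to compound 4 (1.00 log units; beyond the scatter). Compound 1 contributes only a limit to that step, not a number: the limit of < 0.2 uM in this assay, at which 1 of the 4 values shown sits.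

The compounds shown do not tell whether the lower number of compound 4 goes with the aromatic ring itself or with the methyl group on its nitrogen, and the value of a 1H-pyrrol-2-yl group without that methyl stays open. Going by these compounds, it also remains open how a plain phenyl group, a pyridine ring or a chain ending in an amine would behave at this place, and so how far the large gap to compound 1 depends on the trifluoromethyl group.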